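The source may hold more compounds than are shown below. What is called first, only, known or untested is meant among the compounds shown, and "the series" means these compounds.

In an ADME assay on TZM cells (Homo sapiens) for cytotoxicity, with a stated time of 1 days (on this read-out lower numbers stand for higher toxicity in this test and higher numbers for lower toxicity in this test), compound 1 `Cc1cc(CCC#N)cc(C)c1Oc1cc(Nc2ccc(C#N)cc2)c(N)cc1C(=O)N(C)C` gives 38200 nM, compound 2 `Cc1cc(CCC#N)cc(C)c1Oc1cc(Nc2ccc(C#N)cc2)c(N)cc1CN(C)C` gives 23800 nM and compound 3 `Cc1cc(CCC#N)cc(C)c1Oc1cc(Nc2ccc(C#N)cc2)c(N)cc1CNC1CC1` gives 25500 nM. Compound 3 therefore lies within the scatter of both others and holds no distinct rank. Compound 4 `CC(=O)OCc1cc(N)c(Nc2ccc(C#N)cc2)cc1Oc1c(C)cc(CCC#N)cc1C` carries acetoxy in place of cyclopropylamino on a saturated chain carbon bound to an aromatic carbon. Within the data shown here, three measured steps bear on this change: a 1.6-fold lower number from compound 1 to compound 2 (0.21 log units; within the scatter), a 1.5-fold lower number from compound 1 to compound 3 (0.18 log units; within the scatter) and a 1.1-fold higher number from compound 2 to compound 3 (0.03 log units; within the scatter). All three are small, but none introduces acetoxy, so the support is indirect. No step beyond the scatter is expected in this assay, and the estimated change is a 1.0-fold lower number from compound 3 to compound 4 (0.01 log units; within the scatter). For compound 4 the estimated value is 25000 nM, with an expected range of 11000 nM to 55000 nM.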

Compound 4, half-maximal cytotoxic concentration: 44800 nM
Beside the measured number, compound 4's estimate is 1.8-fold (0.25 log units) below it, and the stated range covers the measured number.
By their numbers in this assay, from the lowest: compounds 2, 3, 1 and 4 (each within the scatter of the next).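

Unlike the amine and amide groups before it, acetoxy holds no nitrogen, yet in this assay the readings a 1.8-fold higher number from compound 3 to compound 4 (0.24 log units; within the scatter) and a 1.9-fold higher number from compound 2 to compound 4 (0.27 log units; within the scatter) and a 1.2-fold higher number from compound 1 to compound 4 (0.07 log units; within the scatter) all show no step beyond the scatter. On the saturated chain carbon bound to an aromatic carbon, this test therefore does not separate acetoxy from the two amines. Nothing here gives a reason for this result.

From the compounds shown here alone, whether a carboxylic acid, a hydroxyl or a longer chain at this place would move the number beyond the scatter stays open.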